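Compound 3 to compound 4: replacing the methoxy group

The source may hold more compounds than are shown below. What is called first, only, known or untested is meant among the compounds shown, and "the series" means these compounds.

Compound 1 `CNc1nc(NC2(C#N)CCCCC2)nc(-n2cncn2)n1`: 52 mL/min/kg
Compound 2 `CNc1nc(NC2(C#N)CCCCC2)nc(-n2ccnc2)n1`: 52 mL/min/kg
Compound 3 `CNc1nc(NC2(C#N)CCCCC2)nc(OC)n1`: 196 mL/min/kg

All three compounds were measured in an ADME assay on microsomes from liver (Rattus norvegicus) for metabolic stability; on this read-out lower numbers stand for slow clearance and higher numbers for fast clearance. Compound 3 has the highest number of the three, and it stands clearly apart from the other two. Placing 1H-imidazol-1-yl where 1H-1,2,4-triazol-1-yl sat gave no change at the digits printed from compound 1 to compound 2 (within the scatter).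

The next compound, compound 4 `CNc1nc(NC2(C#N)CCCCC2)nc(-n2cnc(C#N)n2)n1`, carries 3-cyano-1H-1,2,4-triazol-1-yl in place of the methoxy group of compound 3: 3-cyano-1H-1,2,4-triazol-1-yl in place of methoxy on an aromatic carbon.

For the measured compounds named here, two measured steps bear on this change, both running from a ring substituent to methoxy. They are a 3.8-fold higher number from compound 1 to compound 3 (0.58 log units; beyond the scatter) and a 3.8-fold higher number from compound 2 to compound 3 (0.58 log units; beyond the scatter). The new step runs the opposite way, so a drop of similar size is the natural expectation, and the 1H-1,2,4-triazol-1-yl group of compound 1 is the closest measured match. Going by the values given here, no measured compound shows what the added nitrile does to the number, so the range has to stay wide on both sides. The expected change is a 3.6-fold lower number from compound 3 to compound 4 (0.55 log units; beyond the scatter). For compound 4 the estimated value is 55 mL/min/kg, with an expected range of 25 mL/min/kg to 120 mL/min/kg.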

Compound 4, clearance: 210 mL/min/kg
Compound 4: middle estimate off by 3.8-fold (0.58 log units), on the low side; the whole stated range lies below it.
By their numbers in this assay, from the lowest: compounds 1 and 2 (each within the scatter of the next); then compounds 3 and 4 (each within the scatter of the next).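

In this assay the nitrile weighs more at this position than the choice of ring: adding it to the triazole gives a 4.0-fold higher number from compound 1 to compound 4 (0.61 log units; beyond the scatter) in a single change, while the swap of triazole for imidazole had left the number where it was, and a 4.0-fold higher number from compound 2 to compound 4 (0.61 log units; beyond the scatter) is a step of the same size. A five-membered aromatic ring on this aromatic carbon therefore does not by itself go with the lower numbers of compound 1 and compound 2, and with a 1.1-fold higher number from compound 3 to compound 4 (0.03 log units; within the scatter) as the printed step, 3-cyano-1H-1,2,4-triazol-1-yl and methoxy cannot be told apart on this read-out. Nothing among the data shown explains why the nitrile has this effect.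

Going by these compounds, it remains open whether the rise belongs to the nitrile alone or would also appear with another group in the same place on the triazole, such as a methyl, an amine or a carboxylic acid. On these data alone, it is equally open whether a nitrile on the imidazole of compound 2 would behave as it does on the triazole of compound 1, so the result so far rests on one ring and one added group.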